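This account rests on a few compounds, and the source may have more. Where it says the series, first, only, none or still open, it means among the compounds named here.

Working notes on the series. The shared core carries an amide on one side and an amine on the other; compound 1 `CCCNc1cc2c(cn1)cc(NC(=O)c1cccc(-c3ccccc3)c1)c(=O)n2C` gives 6000 nM in a functional assay on MCF7 cells (Homo sapiens) for antiproliferative activity, read by MTT assay, with a stated time of 48 h (on this read-out higher numbers stand for weaker inhibition and lower numbers for stronger inhibition), compound 3 `COc1cc(C(=O)Nc2cc3cnc(NCCN(C)C)cc3n(C)c2=O)cc(OC)c1OC` gives 21500 nM, and compound 2 `CN(C)CCNc1cc2c(cn1)cc(NC(=O)c1ccc(N)cc1)c(=O)n2C` gives 55800 nM, the highest of the three numbers, with compound 3 nearest and compound 1 furthest from it, both gaps beyond the scatter. Compound 4 `CC(=O)Nc1cc2cnc(NCCN(C)C)cc2n(C)c1=O` has not been measured. It differs from compound 2 in one place: methyl in place of 4-aminophenyl on a carbonyl carbon. Among the compounds with values here, no measured pair shows this change, so the expected step in this assay is a small further rise, roughly a 1.4-fold higher number from compound 2 to compound 4 (0.16 log units; within the scatter), with a real chance that only a limit is returned. Compound 4 is estimated at 80000 nM, range 30000 nM to 250000 nM.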

Compound 4, half-maximal inhibitory concentration: > 100000 nM
Compound 4: no number, only a limit; the forecaster's own chance of this, stated with the estimate: 30%; middle value at least 1.2-fold (0.09 log units) from the limit.
By their numbers in this assay, from the lowest: compound 1; then compound 3; then compound 2. At a limit, above all of these: compound 4.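

Methyl in place of 4-aminophenyl on a carbonyl carbon gives the only one-place step in the series, an at least 1.7-fold higher number from compound 2 to compound 4 (0.25 log units; that floor lies within the scatter), and that figure is only a floor. In this assay compound 4 gives > 100000 nM, which is a limit and not a number. This position therefore tolerates this change without returning a measurable value, and the true size of the step stays unknown: the limit of > 100000 nM in this assay, at which 1 of the 4 values shown sits.

The step does not separate the aromatic ring from its amine. As far as these compounds go, whether plain phenyl or cyclohexyl on this carbonyl carbon would return a number remains open.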